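Three Close Values and a Switch to Fluoro

The source may report more compounds than this note shows. Statements on the series, on what has been measured and on what is new or still open speak of the compounds shown alone.

Compound 1 `COC[C@H]1O[C@@H](n2c(Cl)nc3cc(Cl)c(Cl)cc32)[C@H](OC(C)=O)[C@@H]1OC(C)=O` gives 80000 nM
Compound 2 `CSCC1OC(n2c(Cl)nc3cc(Cl)c(Cl)cc32)C(OC(C)=O)C1OC(C)=O` gives 70000 nM
Compound 3 `COC[C@H]1OC(n2c(Cl)nc3cc(Cl)c(Cl)cc32)[C@H](O)[C@@H]1O` gives 90000 nM

All three numbers come from a functional assay on KB cells (Homo sapiens) for inhibition (on this read-out lower numbers stand for stronger inhibition and higher numbers for weaker inhibition), and lie within the usual scatter of one another. Neither compound 1 nor compound 2 stands clearly apart from compound 3, whose 90000 nM sits level with both.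

The next compound to consider is compound 4 `O[C@@H]1[C@@H](CF)OC(n2c(Cl)nc3cc(Cl)c(Cl)cc32)[C@@H]1O`, which keeps the shared core. The change (fluoro in place of methoxy on a saturated chain carbon bound to a saturated ring carbon) places fluoro in place of methoxy on a saturated chain carbon bound to a saturated ring carbon, turning methoxymethyl into fluoromethyl.

For the measured compounds named here, no two measured compounds differ in just one place, so the data offer no direct guide to this change. The only hint is how tightly the three values group, so no step beyond the scatter is expected in this assay here. The expected outcome is a 1.3-fold lower number from compound 3 to compound 4 (0.11 log units; within the scatter) and nothing larger. Compound 4 is estimated at 70000 nM (expected range 25000 nM to 120000 nM).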

Compound 4, half-maximal inhibitory concentration: > 100000 nM
Compound 4 was reported as a limit; the forecaster's own chance of this, stated with the estimate: 25%; middle value at least 1.4-fold (0.15 log units) from the limit.
By their numbers in this assay, from the lowest: compounds 2, 1 and 3 (each within the scatter of the next). At a limit, above all of these: compound 4.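

In this assay, compound 4 gives > 100000 nM, which is a limit of the assay and not an exact number. As far as these compounds go, putting fluoro in place of methoxy on a saturated chain carbon bound to a saturated ring carbon, which turns methoxymethyl into fluoromethyl, gives an at least 1.1-fold higher number from compound 3 to compound 4 (0.04 log units; that floor lies within the scatter), so this single-place change brings no gain in inhibition, though the true size of the step remains unknown. What can be said about this change rests on a single limit: the limit of > 100000 nM in this assay, at which 1 of the 4 values shown sits.

From the compounds shown here alone, it remains open whether an amine, a carboxylic acid or a longer chain in this place would shift the number beyond the scatter. Going by these compounds, the actual value of compound 4 also remains open, and with it whether the change from methoxymethyl to fluoromethyl weakens inhibition at all.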